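Cytotoxicity of Bridged Diamines: Pyrrolidinyl Against Dimethylamino

The source may hold more compounds than are shown below. What is called first, only, known or untested is meant among the compounds shown, and "the series" means these compounds.

Compound 1 `c1ccc(C2CC3(N4CCCC4)CC(NCCN4CCCC4)C2C(c2ccccc2)C3)cc1`: 28400 nM
Compound 2 `c1ccc(C2CC3(N4CCCC4)CCN(CCN4CCCC4)C2C(c2ccccc2)C3)cc1`: 58200 nM
Compound 3 `CN(C)C12CCN(CCN3CCCC3)C(C(c3ccccc3)C1)C(c1ccccc1)C2`: 80400 nM

Of the compounds shown here, three have been measured in an ADME assay on L6 cells (Rattus norvegicus) for cytotoxicity; a higher number here means a weaker inhibitor, a lower number a stronger inhibitor. Compound 1 gives the lowest of the three numbers, and its gaps to compound 2 and to compound 3 both lie beyond the usual scatter. The difference between the cores of compound 1 and compound 2 is not broken down here. Compound 2 and compound 3 differ in one place, (dimethylamino in place of pyrrolidin-1-yl on a saturated ring carbon), and that step, a 1.4-fold higher number from compound 2 to compound 3 (0.14 log units; within the scatter), stays within the scatter.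

Compound 4 `CN(C)C12CC(NCCN3CCCC3)C(C(c3ccccc3)C1)C(c1ccccc1)C2` has not yet been measured. Going by the values given here, it carries the same kind of change relative to compound 1, (dimethylamino in place of pyrrolidin-1-yl on a saturated ring carbon), but the surroundings differ: in compound 1 the ring atom bearing a (2-(pyrrolidin-1-yl)ethyl)amino group and the one bearing a phenyl group flank the place, whereas in compound 2 two ring atoms each bear a phenyl group. Because the earlier step of a 1.4-fold higher number from compound 2 to compound 3 (0.14 log units; within the scatter) was small, the step from compound 1 to compound 4 is expected to be similarly small, about a 1.3-fold higher number from compound 1 to compound 4 (0.13 log units; within the scatter). Compound 4 is therefore estimated at 38000 nM, between 18000 nM and 80000 nM.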

Compound 4, half-maximal inhibitory concentration: 22800 nM
Estimate against measurement, compound 4: 1.7-fold (0.22 log units) above; measured number inside the range.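

In this assay, placing dimethylamino where pyrrolidin-1-yl stood on a saturated ring carbon gives a 1.2-fold lower number from compound 1 to compound 4 (0.10 log units; within the scatter), so on the core of compound 1 this exchange stays as small as it did on the core of compound 2. Set side by side, the two steps do not differ, and the change carries across these two cores: the same change on two cores in this assay, a 1.4-fold higher number (0.14 log units; within the scatter) from compound 2 to compound 3 and a 1.2-fold lower number (0.10 log units; within the scatter) from compound 1 to compound 4, 1.7-fold (0.24 log units) apart, within the scatter of two such steps

Going by these compounds alone, this rests on only two matched pairs in a single assay, so it sets no rule for other cores and does not show that the two groups would also match in any other measurement.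

The compounds shown leave open whether the step stays this small with other amines at that saturated ring carbon, such as piperidin-1-yl, morpholin-4-yl or a primary amine. They also leave open whether it would hold if the (2-(pyrrolidin-1-yl)ethyl)amino group gave way to a longer chain or a different terminal amine.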